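The source may hold more compounds than are shown below. What is called first, only, known or untested is meant among the compounds shown, and "the series" means these compounds.

Compound 3 `C#Cc1cn(C2O[C@H](CO)[C@H](O)C2=C)c(=O)[nH]c1=O` is measured in a functional assay on L1210 cells (Mus musculus) for cytotoxicity (on this read-out lower numbers stand for stronger inhibition and higher numbers for weaker inhibition), and gives only a limit, > 100 ug/mL, which marks the edge of the assay rather than a number. Compound 1 `C=C1C(n2cc(Cl)c(=O)[nH]c2=O)O[C@H](CO)[C@@H]1O` likewise reaches only a limit, > 100 ug/mL. Compound 2 `C=C1C(n2cc(C)c(=O)[nH]c2=O)O[C@H](CO)[C@@H]1O` gives 50 ug/mL in this assay. Two of the three values thus sit at the limit of > 100 ug/mL in this assay, at which 2 of the 3 values shown sit. The step of an at least 2.0-fold higher number from compound 2 to compound 3 (0.30 log units; that floor lies within the scatter) bears most directly on the change ahead, while a step that the two limits leave unreadable from compound 1 to compound 3 adds nothing readable. Compound 4 `C=C1C(n2cc(CC)c(=O)[nH]c2=O)O[C@H](CO)[C@@H]1O` carries ethyl in place of ethynyl on an aromatic carbon. Like methyl in compound 2, ethyl brings no triple bond, so a value near that of compound 2 or at the limit both remain plausible. Compound 4 is therefore expected to give 100 ug/mL, from 40 ug/mL to 250 ug/mL, an expected step of a number no higher from compound 3 to compound 4 (the limit leaves the size open).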

Compound 4, half-maximal inhibitory concentration: > 100 ug/mL
Compound 4: a limit, no number; the forecaster's own chance of this, stated with the estimate: 50%; the middle value sits exactly at the limit.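

Adding one carbon to the methyl of compound 2 gives an at least 2.0-fold higher number from compound 2 to compound 4 (0.30 log units; that floor lies within the scatter), so among the groups shown at this position only methyl yields a real number in this assay, though that floor alone does not separate the two compounds. Compound 3 and compound 4 both end at a limit, so losing the triple bond brings no readable gain. Because both ends are limits, the steps from compound 1 and compound 3 to compound 4 cannot be read: the limit of > 100 ug/mL in this assay, at which 3 of the 4 values shown sit.

Going by these compounds, how far compound 4 lies past the limit stays open. So does how an amine or a longer chain would read at this position.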